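Swapping the cyanoaryl group: compound 2 to compound 3

A few compounds are considered here, and "the series" means these few. Any claim that something is new, unique, unknown or untested is made for them only; others in the source may bear on it.

In a functional assay on EBC-1 cells (Homo sapiens) for antiproliferative activity, with a stated time of 72 h (on this read-out higher numbers stand for weaker inhibition and lower numbers for stronger inhibition), compound 1 (`Cn1cc(-c2cc(F)c3ncc(Cc4ccc5ncccc5c4)n3c2)cn1`) gives 0.27 nM, while compound 2 (`N#Cc1ccc(-c2cc(F)c3ncc(Cc4ccc5ncccc5c4)n3c2)cn1`) gives 189 nM, the higher of the two numbers. Compound 3 (`N#Cc1ccc(-c2cc(F)c3ncc(Cc4ccc5ncccc5c4)n3c2)cc1F`) differs from compound 2 in one place: 4-cyano-3-fluorophenyl in place of 6-cyanopyridin-3-yl on an aromatic carbon. Going by the values given here, only one measured step bears on this, and only indirectly: a 700-fold higher number from compound 1 to compound 2 (2.85 log units; beyond the scatter). That large step involved 1-methyl-1H-pyrazol-4-yl, whereas the new change keeps a nitrile on a six-membered aromatic ring. No step beyond the scatter is therefore expected, and the estimated step is a 1.6-fold lower number from compound 2 to compound 3 (0.20 log units; within the scatter). For compound 3 the expected value is 120 nM, with an estimated range of 25 nM to 500 nM.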

Compound 3, half-maximal inhibitory concentration: 145 nM
Estimate against measurement, compound 3: 1.2-fold (0.08 log units) below, and the stated range covers the measured number.
By their numbers in this assay, from the lowest: compound 1; then compounds 3 and 2 (each within the scatter of the next).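

In this assay, 4-cyano-3-fluorophenyl and 6-cyanopyridin-3-yl on this aromatic carbon cannot be told apart (a 1.3-fold lower number from compound 2 to compound 3 (0.12 log units; within the scatter)). The large gap to 1-methyl-1H-pyrazol-4-yl therefore recurs with a second cyanoaryl group, one whose ring is carbon only (a 540-fold higher number from compound 1 to compound 3 (2.73 log units; beyond the scatter)). Nothing available points to a cause for either step.

Open, on these data alone, is whether the gap follows the nitrile or the six-membered ring: a carboxylic acid or an amine in place of the nitrile could separate the two. Also open, as far as these compounds go, is whether a longer chain on the pyrazole nitrogen holds the number of compound 1.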